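Swapping an Ethyl Ether Tail for an Ester-Bearing Chain

The compounds below may be only part of what the source reports. "The series", "measured", "known", "first", "only" and "open" are said of these compounds alone.

Of the compounds shown here, two that share one core have been measured so far. In an assay on isolated protein (strain Sprague-Dawley) for inhibition of Amine oxidase [flavin-containing] B (Rattus norvegicus), read by spectrophotometry, with a stated time of 5 min (on this read-out lower numbers stand for stronger inhibition and higher numbers for weaker inhibition), compound 1 `CCOc1cc(=O)oc2cc(OCc3cccc(F)c3)ccc12` gives 263 nM. In this assay compound 2 `CCOc1cc(=O)oc2cc(OCc3cccc(Cl)c3)ccc12` gives 115 nM. Among the compounds with values here, the only measured step, a 2.3-fold lower number from compound 1 to compound 2 (0.36 log units; beyond the scatter), is a change of chloro in place of fluoro on an aromatic carbon. Compound 2 therefore stands lowest of the two numbers, with compound 1 the nearest.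

Compound 3 `CCOC(=O)COc1cc(=O)oc2cc(OCc3cccc(Cl)c3)ccc12` differs from compound 2 by ethoxycarbonyl in place of methyl on a saturated chain carbon bound to an oxygen on an aromatic ring. Within the data shown here, this change touches a different part of the molecule from the halogen swap, so no measured step bears on it, and the direction of any shift cannot be read from the data; an ester-bearing chain is simply untested here. Compound 3 is expected to lie near 180 nM, within 45 nM to 700 nM. That expectation corresponds to a 1.6-fold higher number from compound 2 to compound 3 (0.19 log units; within the scatter), a step expected to be small and uncertain.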

Compound 3, half-maximal inhibitory concentration: 1820 nM
Compound 3: middle estimate off by 10-fold (1.00 log units), on the low side; the whole stated range lies below it.
By their numbers in this assay, from the lowest: compound 2; then compound 1; then compound 3.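

In this assay, the end of the molecule carrying the ethyl ether proves sensitive to what is attached there: ethoxycarbonyl in place of methyl gives a 16-fold higher number from compound 2 to compound 3 (1.20 log units; beyond the scatter), a larger move than the halogen swap, which gave a 2.3-fold lower number from compound 1 to compound 2 (0.36 log units; beyond the scatter). This position therefore does not accept any added group freely, and this longer chain, with its two hydrogen-bond acceptors, goes with much weaker inhibition. No measurement shown here accounts for the rise.

From the compounds shown here alone, with only one replacement at this position, it remains open whether the rise follows from the added length or from the ester itself, a question that a plain butoxy chain or a carboxylic acid in place of the ester could help to settle. Going by these compounds, it is also open whether the ethoxycarbonyl change would produce a similar step on the fluoro compound 1.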